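The source may report more compounds than this note shows. Statements on the series, on what has been measured and on what is new or still open speak of the compounds shown alone.

Compound 1 `CC(C)CCC(=O)Nc1c(C(O)(C(F)(F)F)C(F)(F)F)ccc2ccccc12` carries an isopentyl group on its carbonyl carbon, and in an assay on LtK cells with ATP-sensitive inward rectifier potassium channel 11 (Homo sapiens) as the target (on this read-out higher numbers stand for an effect only at larger amounts of compound and lower numbers for an effect already at smaller amounts), compound 1 gives 49 nM. Compound 2 `O=C(Nc1c(C(O)(C(F)(F)F)C(F)(F)F)ccc2ccccc12)c1cccc(Cl)c1Cl` has a 2,3-dichlorophenyl group on that carbonyl carbon, and in this assay compound 2 reaches only the limit of > 10000 nM. Within the data shown here, the single measured step, an at least 200-fold higher number from compound 1 to compound 2 (2.30 log units; beyond the scatter), rests on that limit (the limit of > 10000 nM in this assay, at which 1 of the 2 values shown sits). Compound 3 `O=C(Nc1c(C(O)(C(F)(F)F)C(F)(F)F)ccc2ccccc12)c1cccs1` brings (thiophen-2-yl in place of 2,3-dichlorophenyl on a carbonyl carbon). Among the measured compounds shown here, no measured step covers this change, so its direction remains open. Compound 3 is expected near 3000 nM, within 400 nM to 20000 nM. The expected step is an at least 3.3-fold lower number from compound 2 to compound 3 (0.52 log units; beyond the scatter).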

Compound 3, half-maximal effective concentration: 12 nM
The estimate for compound 3 lay 250-fold (2.40 log units) above the measured number, and the stated range ends above it.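

An aromatic ring on this carbonyl carbon does not by itself end the effect in this assay: the change to thiophen-2-yl brings an at least 830-fold lower number from compound 2 to compound 3 (2.92 log units; beyond the scatter). The thiophen-2-yl group also goes past the isopentyl group, with a 4.1-fold lower number from compound 1 to compound 3 (0.61 log units; beyond the scatter). The first of these steps rests on a limit for compound 2, not on a number: the limit of > 10000 nM in this assay, at which 1 of the 3 values shown sits.

Still open, from the compounds shown here alone, is whether the two chlorines or the six-membered carbon ring accounts for the weak result of compound 2; a plain phenyl group would separate the two. Also open, going by these compounds, is how a furan-2-yl group or an amine on this carbonyl carbon would read.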